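From nitro to cyano in a level series

This account rests on a few compounds, and the source may have more. Where it says the series, first, only, none or still open, it means among the compounds named here.

- Compound 1 `CC[C@H]1CC[C@H](c2ccc(NC(=S)Nc3cccc(C(F)(F)F)c3)cc2)CC1` gives 10000 nM
- Compound 2 `FC(F)(F)c1cccc(NC(=S)Nc2ccc(I)cc2)c1` gives 9400 nM
- Compound 3 `O=[N+]([O-])c1ccc(NC(=S)Nc2cccc(C(F)(F)F)c2)cc1` gives 9500 nM

These three values come from an ADME assay on BHK cells (Mesocricetus auratus) for cytotoxicity, read by MTT assay, with a stated time of 96 h; a higher number here means that more compound is tolerated, a lower number that less compound is tolerated. Compound 3 stands level with the other two, and the numbers set no order among them. The measured gaps are a 1.1-fold lower number from compound 1 to compound 3 (0.02 log units; within the scatter) and a 1.0-fold higher number from compound 2 to compound 3 (0.00 log units; within the scatter).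

The next molecule is compound 4 `N#Cc1ccc(NC(=S)Nc2cccc(C(F)(F)F)c2)cc1`, which keeps the shared core and changes one group: cyano in place of nitro on an aromatic carbon. This is cyano in place of nitro on an aromatic carbon, para to a large group.

All three measured steps bear on this change, since each exchanges the group at that same place. Besides the two gaps above, the data show a 1.1-fold lower number from compound 1 to compound 2 (0.03 log units; within the scatter). So 4-ethylcyclohexyl, iodo and nitro have all been exchanged there without any step beyond the scatter, and no compound here goes against that. For the measured compounds named here, no measured compound carries cyano, however, so the expectation is carried over from other groups.

The expected result is no change beyond the scatter, with no preferred direction: the estimate is no change at the digits printed from compound 3 to compound 4 (within the scatter). For compound 4 the estimated value is 9500 nM, with an expected range from 5500 nM to 14000 nM.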

Compound 4, half-maximal cytotoxic concentration: 9500 nM
The estimate for compound 4 equals the measured number at the digits printed; measured number inside the range.
By their numbers in this assay, from the lowest: compounds 2, 3, 4 and 1 (each within the scatter of the next).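

In this assay, cyano now joins the groups tested at this place on the aromatic ring, and the exchange for nitro gives (no change at the digits printed from compound 3 to compound 4 (within the scatter)). The same group compared with the other two gives (a 1.0-fold higher number from compound 2 to compound 4 (0.00 log units; within the scatter)) and (a 1.1-fold lower number from compound 1 to compound 4 (0.02 log units; within the scatter)). Cyano is the only group here with a triple bond, so four different groups, para to a large group, now stand level, and no compound shown goes against that, though nothing measured here tells why the numbers stay level.

From the compounds shown here alone, it remains open whether every kind of group is tolerated equally at this place, since an amine, a carboxylic acid or a longer chain might or might not fit the level picture set by these four compounds. All four compounds also carry the same trifluoromethyl group and the same remaining core, so they say nothing about how the number would respond to a change there, such as a methyl group or a chlorine atom in place of trifluoromethyl.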